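The source may report more compounds than this note shows. Statements on the series, on what has been measured and on what is new or still open speak of the compounds shown alone.

Compound 1, `CCCn1c(Cc2cc(OC)c(OC)c(OC)c2)nc2c(N)ncnc21`, gives 46800 nM in a functional assay on MCF7 cells (Homo sapiens) for antiproliferative activity; a higher number here means a weaker inhibitor, a lower number a stronger inhibitor. Compound 2, `CCCCCn1c(Cc2cc(OC)c(OC)c(OC)c2)nc2c(N)ncnc21`, gives 61700 nM. Compound 3, `COc1cc(Cc2nc3c(N)ncnc3n2CC2CCC2)cc(OC)c1OC`, gives 45700 nM.

On these numbers compound 3 sits at the low end, yet neither gap is a real one: the step of a 1.0-fold lower number from compound 1 to compound 3 (0.01 log units; within the scatter) and the step of a 1.4-fold lower number from compound 2 to compound 3 (0.13 log units; within the scatter) both stay within the scatter, as does the step of a 1.3-fold higher number from compound 1 to compound 2 (0.12 log units; within the scatter). Compound 4, `CCC(C)Cn1c(Cc2cc(OC)c(OC)c(OC)c2)nc2c(N)ncnc21`, differs from compound 3 by sec-butyl in place of cyclobutyl on a saturated chain carbon bound to an aromatic nitrogen. The steps that bear on this are the three already shown, since each of them also changes only the saturated chain on the carbon bound to the aromatic nitrogen: propyl, pentyl and cyclobutylmethyl all land within the scatter of one another. Nothing in the shown data points to a sec-butyl chain behaving differently, so the step of a 1.1-fold higher number from compound 3 to compound 4 (0.02 log units; within the scatter) is expected to stay within the scatter, with no clear direction. Compound 4 is therefore estimated at 48000 nM in this assay, with a range from 25000 nM to 95000 nM.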

Compound 4, half-maximal inhibitory concentration: 61700 nM
Compound 4: middle estimate off by 1.3-fold (0.11 log units), on the low side, within the range that was stated.
By their numbers in this assay, from the lowest: compounds 3, 1, 2 and 4 (each within the scatter of the next).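

In this assay, sec-butyl in place of cyclobutyl on a saturated chain carbon bound to an aromatic nitrogen removes the ring while keeping the same number of carbons, and this gives a 1.4-fold higher number from compound 3 to compound 4 (0.13 log units; within the scatter). The earlier compounds shown here held only unbranched chains and the ring, and the branched chain also stays within the scatter of both unbranched chains, with no change at the digits printed from compound 2 to compound 4 (within the scatter) and a 1.3-fold higher number from compound 1 to compound 4 (0.12 log units; within the scatter), so ring, branch and chain length have not separated at this position. No supporting evidence bears on this result.

Going by these compounds, all four compounds carry only saturated carbon groups here, so whether an amine, a carboxylic acid or a much longer chain would move the number beyond the scatter stays open. On these data alone, whether changes elsewhere on the shared core would do so also stays open.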